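The source may hold more compounds than are shown below. What is called first, only, known or untested is meant among the compounds shown, and "the series" means these compounds.

In an ADME assay on MDBK cells (Bos taurus) for cytotoxicity, read by MTT assay, with a stated time of 96 h (on this read-out lower numbers stand for higher toxicity in this test and higher numbers for lower toxicity in this test), compound 3 (`CC(=O)c1ccc2[nH]c(-c3ccoc3)nc2c1`) stands at >= 100000 nM as a limit of the test, not as a number. Compound 4 (`C/C(=N\NC(N)=O)c1ccc2[nH]c(-c3ccoc3)nc2c1`) differs from it by one swap on an aromatic carbon (a group of 7 heavy atoms (3 carbon, 3 nitrogen, 1 oxygen; no ring) in place of a group of 3 heavy atoms (2 carbon, 1 oxygen; no ring), on an aromatic carbon). Among the measured compounds shown here, no measured step makes this swap directly. Compound 1 (`C/C(=N\NC(N)=O)c1ccc2[nH]c(-c3ccccc3)nc2c1`) already carries the entering group and stands at > 100000 nM as a limit as well. Compound 2 (`COc1ccc(-c2nc3cc(/C(C)=N/NC(N)=O)ccc3[nH]2)cc1`) carries that group plus a methoxy and gives 25000 nM in this assay as a measured number. Methoxy in place of hydrogen thus brought an at least 4.0-fold lower number from compound 1 to compound 2 (0.60 log units; beyond the scatter) as the only measured step, and compound 4 has no methoxy. A modest fall or nothing beyond the scatter is therefore expected in this assay for the step (an at least 1.4-fold lower number from compound 3 to compound 4 (0.15 log units; that floor lies within the scatter)). For compound 4 the estimate is 70000 nM with an estimated range (25000 nM to 100000 nM).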

Compound 4, half-maximal cytotoxic concentration: > 100000 nM
Compound 4 was reported as a limit; the forecaster's own chance of this, stated with the estimate: 45%; at least 1.4-fold (0.15 log units) between middle value and limit.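

In this assay, furan-3-yl in place of 4-methoxyphenyl gives an at least 4.0-fold higher number from compound 2 to compound 4 (0.60 log units; beyond the scatter). With this group of 7 heavy atoms on the aromatic carbon, compound 2 alone gives a measured number, so that group does not by itself bring a measurable value. The steps to compound 4 from compound 3 and from compound 1 each join two limits and cannot be read.

Still open, on these data alone, is whether the lower number in compound 2 is specific to methoxy. An amine or a carboxylic acid at that place on the phenyl could show this.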